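From compound 3 to compound 4: one amine exchanged

A few compounds are considered here, and "the series" means these few. Any claim that something is new, unique, unknown or untested is made for them only; others in the source may bear on it.

Measured in a functional assay on SK-BR-3 cells (Homo sapiens) for antiproliferative activity; a higher number here means a weaker inhibitor, a lower number a stronger inhibitor:
- compound 1 `CCN(C)CCCOc1ccc2cc(NC(=O)c3ccc(O)c(CC=C(C)C)c3)c(=O)oc2c1C`: 730 nM
- compound 2 `CC(C)=CCc1cc(C(=O)Nc2cc3ccc(OCCCNC(C)(C)C)c(C)c3oc2=O)ccc1O`: 660 nM
- compound 3 `COC(=O)CNCCCOc1ccc2cc(NC(=O)c3ccc(O)c(CC=C(C)C)c3)c(=O)oc2c1C`: 1060 nM

Compound 3 stands within the scatter of both other compounds, as a 1.5-fold higher number from compound 1 to compound 3 (0.16 log units; within the scatter) and a 1.6-fold higher number from compound 2 to compound 3 (0.21 log units; within the scatter) show. Compound 4 `CC(C)=CCc1cc(C(=O)Nc2cc3ccc(OCCCN(C)c4ccccc4)c(C)c3oc2=O)ccc1O` differs from it by methyl(phenyl)amino in place of ((methoxycarbonyl)methyl)amino on a saturated chain carbon, three bonds along the chain from an oxygen on an aromatic ring: methyl(phenyl)amino in place of ((methoxycarbonyl)methyl)amino, on a saturated chain carbon, three bonds along the chain from an oxygen on an aromatic ring. All three measured exchanges at this place stayed small, including a 1.1-fold lower number from compound 1 to compound 2 (0.04 log units; within the scatter). None of them, however, introduced a phenyl group, so the data do not cover that feature directly. No step beyond the scatter is therefore expected in this assay, in either direction. The expected step is a 1.3-fold lower number from compound 3 to compound 4 (0.12 log units; within the scatter). For compound 4 the estimate is 800 nM, with an expected range of 350 nM to 1800 nM.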

Compound 4, half-maximal inhibitory concentration: > 50000 nM
Compound 4 gave a limit, no number (the forecaster's own chance of this, stated with the estimate: 3%); middle value at least 62-fold (1.79 log units) from the limit.
By their numbers in this assay, from the lowest: compounds 2, 1 and 3 (each within the scatter of the next). At a limit, above all of these: compound 4.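

In this assay compound 4 gave only a limit, > 50000 nM, and not a number. This place on the saturated chain carbon had taken three different amines with steps within the scatter, but it does not accept every amine: an at least 47-fold higher number from compound 3 to compound 4 (1.67 log units; beyond the scatter), an at least 75-fold higher number from compound 2 to compound 4 (1.87 log units; beyond the scatter) and an at least 68-fold higher number from compound 1 to compound 4 (1.83 log units; beyond the scatter), the last being only phenyl in place of ethyl on an amine nitrogen. All three steps rest on one limit: the limit of > 50000 nM in this assay, at which 1 of the 4 values shown sits.

From the compounds shown here alone, how far beyond that limit compound 4 lies remains open. So does whether a cyclohexyl or a benzyl group on the same amine nitrogen would give the same result as phenyl.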